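Pyridinyl in Place of Thiophenyl on the Sulfonyl Group

The compounds below may be only part of what the source reports. "The series", "measured", "known", "first", "only" and "open" are said of these compounds alone.

Compound 1 `CNCc1cc(-c2cccnc2C#N)n(S(=O)(=O)c2ccccc2)c1` gives 99% in a functional assay on the whole organism (strain Jcl:SD) for inhibition, with Rattus norvegicus as the target, with stated times of 3 min and 3 h, at a dose of 1 mg/kg by the intravenous route; a lower number here means less inhibition, a higher number more inhibition at the dose given (going by the name of the read-out).
Compound 2 `CNCc1cc(-c2ccccc2C)n(S(=O)(=O)c2ccc(C)cc2)c1` gives 92% in this assay.
Compound 3 `CNCc1cc(-c2cccnc2F)n(S(=O)(=O)c2cccs2)c1` gives 96% in this assay.

The value of compound 3 lies between those of compound 1 and compound 2, and both gaps fall within the usual scatter, so the three compounds read essentially alike. Compound 4 `CNCc1cc(-c2cccnc2F)n(S(=O)(=O)c2ccccn2)c1` differs from compound 3 in one place: pyridin-2-yl in place of thiophen-2-yl on a sulfonyl sulfur. Going by the values given here, no measured pair here differs in exactly one place, so no measured step guides the expectation directly. Because compound 3 gives 96% while compound 1 and compound 2 carry quite different groups on the sulfonyl sulfur and still give similar values, the step of a number 1 percentage points lower from compound 3 to compound 4 (within the scatter) is expected to be none beyond the scatter. Compound 4 is estimated at 95%, within a range from 85% to 99%.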

Compound 4, a percentage reported as inhibition, in the whole organism at one dose (the size of the read-out at that dose, not a potency): 81%
For compound 4 the middle estimate is 14 percentage points above the measured one; measured number below the stated range.
By their numbers in this assay, from the lowest: compound 4; then compounds 2, 3 and 1 (each within the scatter of the next).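

In this assay, putting pyridin-2-yl in place of thiophen-2-yl on the sulfonyl sulfur gives a number 15 percentage points lower from compound 3 to compound 4 (beyond the scatter). The earlier compounds shown here differed in several places at once, whereas this pair shows that the group at this position can alone move the number beyond the scatter. Both groups have the same hydrogen-bond counts and no net charge, so those counts do not separate them; ring size and the hetero atom do.

No available measurement explains the drop. Going by these compounds, it remains open whether furan-2-yl or pyridin-3-yl at this position would read closer to compound 3 or compound 4.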